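A Second Acetoxy Group on a Weakly Binding Core

The source may report more compounds than this note shows. Statements on the series, on what has been measured and on what is new or still open speak of the compounds shown alone.

Measured so far:
compound 1, `CC(=O)Oc1cccc2cc(-c3ccccc3)c(=O)oc12`, with 6860 nM
compound 2, `CC(=O)Oc1ccc2cc(-c3ccccc3)c(=O)oc2c1OC(C)=O`, with 5170 nM
compound 3, `CC(=O)Oc1ccc(-c2cc3cccc(OC(C)=O)c3oc2=O)cc1OC(C)=O`, with 22000 nM

All three compounds were tested in an assay on CHO cells for displacement of a labelled ligand from adenosine receptor A3 (Homo sapiens), read by radioligand binding; on this read-out higher numbers stand for weaker inhibition and lower numbers for stronger inhibition. None of them binds tightly. Compound 1 and compound 2 share one core; compound 3 carries a core that differs from that of compound 1, and the difference between the two cores is not broken down here. In this assay compound 3 gives 22000 nM, the highest number of the three, and its gap to compound 1 and to compound 2 lies beyond the usual scatter.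

The step from compound 1 to compound 2 is acetoxy in place of hydrogen on an aromatic carbon, and it gave a 1.3-fold lower number from compound 1 to compound 2 (0.12 log units; within the scatter). The same change is now to be made on the other core: compound 4, `CC(=O)Oc1ccc(-c2cc3ccc(OC(C)=O)c(OC(C)=O)c3oc2=O)cc1OC(C)=O`, not yet measured, differs from compound 3 by acetoxy in place of hydrogen on an aromatic carbon. The place of the change is described in the same words for both pairs.

Because the earlier step was a 1.3-fold lower number from compound 1 to compound 2 (0.12 log units; within the scatter), a step of about the same size is expected for compound 4, so that a 1.3-fold lower number from compound 3 to compound 4 (0.11 log units; within the scatter) is the estimate for the step from compound 3 to compound 4. Compound 4 is therefore expected to give about 17000 nM in this assay, most likely between 6000 nM and 50000 nM, still a weak binder, with some chance that only a limit is reported.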

Compound 4, inhibition constant: 23400 nM
The estimate for compound 4 lay 1.4-fold (0.14 log units) below the measured number; the range from low to high includes it.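

On the core of compound 3, the added acetoxy group gave a 1.1-fold higher number from compound 3 to compound 4 (0.03 log units; within the scatter), so in this assay this step, like the one on the core of compound 1, is too small to tell apart from repeat-measurement noise. Set side by side, the two steps agree, and in this small set the change carries from one core to the other as a step that cannot be distinguished from no change at all: the same change on two cores in this assay, a 1.3-fold lower number (0.12 log units; within the scatter) from compound 1 to compound 2 and a 1.1-fold higher number (0.03 log units; within the scatter) from compound 3 to compound 4, 1.4-fold (0.15 log units) apart, within the scatter of two such steps. Among the compounds shown here, this agreement rests on just two pairs, all four compounds bind only weakly, and two steps lost in the scatter show only that neither core responded measurably, so they establish no general rule and say nothing about why the number stays put, or about how the change would behave on a core that binds tightly.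

The compounds shown leave open whether a different group on this aromatic carbon, such as a hydroxyl, an amine or a carboxylic acid, would give a step beyond the scatter. They also leave open whether an ester with a longer chain in place of the acetoxy group would do so on either core.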